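Permeability notes: cyanomethyl for 1-acetylazetidin-3-yl

The compounds below may be only part of what the source reports. "The series", "measured", "known", "first", "only" and "open" are said of these compounds alone.

Compound 2 `CC(=O)N1CC(C(=O)Nc2ccc(C3CCCCC3)cc2)C1` and compound 1 `N#CCC(=O)Nc1ccc(C2CCCCC2)cc1` share one core. In an ADME assay on MDCK-MDR1 cells (Canis lupus familiaris) for permeability, in the apical to basolateral direction, with a stated time of 180 min (a lower number here means that the compound crosses the layer more slowly, a higher number that the compound crosses the layer faster), compound 2 gives 18.7 10^-6 cm/s, and compound 1 gives 18.6 10^-6 cm/s; the change cyanomethyl in place of 1-acetylazetidin-3-yl on a carbonyl carbon amounts to a 1.0-fold lower number from compound 2 to compound 1 (0.00 log units; within the scatter). Compound 3 `CC(=O)N1CC(C(=O)Nc2ccc([C@H]3[C@@H](F)[C@@H](F)C[C@@H](F)[C@H]3F)cc2)C1` carries a different core; the difference between the two cores is not broken down here. In this assay compound 3 gives 0.6 10^-6 cm/s, the lowest of the three numbers and beyond the scatter from both others. Compound 4 `N#CCC(=O)Nc1ccc([C@H]2[C@@H](F)[C@@H](F)C[C@@H](F)[C@H]2F)cc1` is not yet measured. It differs from compound 3 by cyanomethyl in place of 1-acetylazetidin-3-yl on a carbonyl carbon, the same change as from compound 2 to compound 1, at the same place. Because a 1.0-fold lower number from compound 2 to compound 1 (0.00 log units; within the scatter) lay within the scatter, the expected step is no change at the digits printed from compound 3 to compound 4 (within the scatter). Compound 4 is estimated at 0.6 10^-6 cm/s in this assay, between 0.3 10^-6 cm/s and 1.3 10^-6 cm/s.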

Compound 4, apparent permeability: 16 10^-6 cm/s
Beside the measured number, compound 4's estimate is 27-fold (1.43 log units) below it, and the stated range ends below it.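

In this assay, cyanomethyl in place of 1-acetylazetidin-3-yl on a carbonyl carbon gives a 27-fold higher number from compound 3 to compound 4 (1.43 log units; beyond the scatter). The result of this change therefore does not carry from one core to the other in this series: the same change on two cores in this assay, a 1.0-fold lower number (0.00 log units; within the scatter) from compound 2 to compound 1 and a 27-fold higher number (1.43 log units; beyond the scatter) from compound 3 to compound 4, 27-fold (1.43 log units) apart, beyond the scatter of two such steps. Among these compounds, this shows that the step on one core cannot stand in for the step on the other, but with only two pairs it does not show what in the cores sets them apart or how the change would behave on a third core.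

Still open, as far as these compounds go, is whether a different group at this place on the carbonyl carbon, such as an aminomethyl group, a carboxylic acid or a longer alkyl chain, would follow the pattern of the pair on the core of compound 1 or that on the core of compound 3. Also open, from the compounds shown here alone, is whether other acylated azetidines on the core of compound 3 would stay close to the number of compound 3, which is 0.6 10^-6 cm/s.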